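Sulfonyl substituent change: compound 3 to compound 4

This account rests on a few compounds, and the source may have more. Where it says the series, first, only, none or still open, it means among the compounds named here.

Working notes on the series. In a functional assay on DU-145 cells (Homo sapiens) for cytotoxicity, read by MTT assay, with a stated time of 24 h (on this read-out higher numbers stand for weaker inhibition and lower numbers for stronger inhibition), compound 3 `COc1cc2nc(Cl)nc(NS(=O)(=O)c3ccc(C)cc3)c2cc1OC` gives 44.2 ug/mL, the highest of the three numbers recorded so far. Compound 1 `COc1cc2nc(Cl)nc(NS(=O)(=O)c3ccccc3)c2cc1OC` gives 12.3 ug/mL in this assay, and compound 2 `COc1cc2nc(N3CCCC3)nc(NS(=O)(=O)c3ccc(C)cc3)c2cc1OC` gives 14.1 ug/mL. Both measured steps reach compound 3 and both lie beyond the scatter: a 3.6-fold higher number from compound 1 to compound 3 (0.56 log units; beyond the scatter), and a 3.1-fold higher number from compound 2 to compound 3 (0.50 log units; beyond the scatter).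

Compound 4 `COc1cc2nc(Cl)nc(NS(=O)(=O)c3cccs3)c2cc1OC` is not yet measured. It differs from compound 3 by thiophen-2-yl in place of 4-methylphenyl on a sulfonyl sulfur. For the measured compounds named here, of the two measured steps only one bears on the group attached to the sulfonyl sulfur: a 3.6-fold higher number from compound 1 to compound 3 (0.56 log units; beyond the scatter). The step from compound 2 to compound 3 changes the other position and is not informative here. Going by the values given here, no measured step exchanges the six-membered ring for a five-membered ring with one hetero atom, so that part of the change is unsupported by data.

Among the compounds with values here, because a 3.6-fold higher number from compound 1 to compound 3 (0.56 log units; beyond the scatter) is the only measured step that bears on the group attached to the sulfonyl sulfur and compound 4 removes that methyl along with the ring it sits on, a modest lowering of the number in this assay is expected, a 2.8-fold lower number from compound 3 to compound 4 (0.44 log units; beyond the scatter), toward the level of compound 1. Compound 4 is therefore estimated at 16 ug/mL, with a range of 6 ug/mL to 42 ug/mL.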

Compound 4, half-maximal inhibitory concentration: 16.5 ug/mL
Beside the measured number, compound 4's estimate is 1.0-fold (0.01 log units) below it; the measured number falls inside the stated range.
By their numbers in this assay, from the lowest: compounds 1, 2 and 4 (each within the scatter of the next); then compound 3.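

In this assay, thiophen-2-yl in place of 4-methylphenyl on the sulfonyl sulfur gives a clear change (a 2.7-fold lower number from compound 3 to compound 4 (0.43 log units; beyond the scatter)), which shows that this position also accepts a five-membered aromatic ring with 1 hetero atom. Set against phenyl, the same group gives no change that can be read (a 1.3-fold higher number from compound 1 to compound 4 (0.13 log units; within the scatter)), so with chloro held constant, 4-methylphenyl alone stands apart among the three groups on the sulfonyl sulfur. Nothing measured accounts for this result.

The compounds shown leave open whether the higher number of compound 3 is particular to the methyl group or would recur with a methoxy or chloro group on the phenyl ring. They also leave open how thiophen-2-yl behaves with pyrrolidin-1-yl in place of chloro, and whether a saturated ring such as cyclohexyl fits on the sulfonyl sulfur.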